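Spiro Amides: Predicting a Piperazinyl Analogue's Cholesterol-Transporter Binding

The source may report more compounds than this note shows. Statements on the series, on what has been measured and on what is new or still open speak of the compounds shown alone.

Measured compounds:
compound 1 `CC(C)(C)c1ccc(C(=O)N2CCC3(CC2)C(=O)N(CC(=O)NCCCN)CN3c2ccccc2)cc1`: 4200 nM
compound 2 `CC1CCCN(C(=O)CN2CN(c3ccccc3)C3(CCN(C(=O)c4ccc(C(C)(C)C)cc4)CC3)C2=O)C1`: 12000 nM
compound 3 `CC1(C)CC(OC(=O)CN2CN(c3ccccc3)C3(CCN(C(=O)c4ccc(C(C)(C)C)cc4)CC3)C2=O)CC(C)(C)N1`: 1300 nM

Of the compounds shown here, three sharing one core have been tested in an assay on HEK293 cells for displacement of a labelled ligand from NPC1-like intracellular cholesterol transporter 1 (Homo sapiens); a higher number here means a weaker inhibitor, a lower number a stronger inhibitor. Compound 3 stands lowest of the three: compound 1 sits nearest, with a 3.2-fold lower number from compound 1 to compound 3 (0.51 log units; beyond the scatter), and compound 2 furthest, with a 9.2-fold lower number from compound 2 to compound 3 (0.97 log units; beyond the scatter). Between the two amide-bearing compounds themselves, a 2.9-fold higher number from compound 1 to compound 2 (0.46 log units; beyond the scatter).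

Compound 4 `CC(C)(C)c1ccc(C(=O)N2CCC3(CC2)C(=O)N(CC(=O)N2CCNCC2)CN3c2ccccc2)cc1` is the next member. (piperazin-1-yl in place of (2,2,6,6-tetramethylpiperidin-4-yl)oxy on a carbonyl carbon). The change thus moves away from the (2,2,6,6-tetramethylpiperidin-4-yl)oxy group of compound 3, which gave the lowest number, toward a piperazin-1-yl group that resembles the six-membered non-aromatic rings attached to the carbonyl carbon in compound 2 while retaining a hydrogen-bond donor like compound 1. The two steps that bear on this, a 3.2-fold lower number from compound 1 to compound 3 (0.51 log units; beyond the scatter) and a 9.2-fold lower number from compound 2 to compound 3 (0.97 log units; beyond the scatter), both show that leaving the (2,2,6,6-tetramethylpiperidin-4-yl)oxy group raised the number by a modest amount. Compound 4 is therefore expected to give a higher number in this assay than compound 3, an estimated 4.6-fold higher number from compound 3 to compound 4 (0.66 log units; beyond the scatter). The value for compound 4 is estimated at 6000 nM, most likely between 2000 nM and 20000 nM.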

Compound 4, half-maximal inhibitory concentration: 22000 nM
The estimate for compound 4 lay 3.7-fold (0.56 log units) below the measured number; measured number above the stated range.
By their numbers in this assay, from the lowest: compound 3; then compound 1; then compounds 2 and 4 (each within the scatter of the next).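

In this assay, piperazin-1-yl on this carbonyl carbon brings a 17-fold higher number from compound 3 to compound 4 (1.23 log units; beyond the scatter), the largest listed step in the series, even though the leaving and entering groups each count one hydrogen-bond donor and one six-membered non-aromatic ring; against the other ring group, the change brings a 1.8-fold higher number from compound 2 to compound 4 (0.26 log units; within the scatter), so piperazin-1-yl and 3-methylpiperidin-1-yl are not told apart at this position. The open-chain (3-aminopropyl)amino group also compares favourably with piperazin-1-yl, with a 5.2-fold higher number from compound 1 to compound 4 (0.72 log units; beyond the scatter), so compound 3 and compound 1 both hold lower numbers than compound 4, and the position clearly responds to the group placed there. Nothing available here accounts for these differences.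

The compounds shown leave open whether the low number of compound 3 goes with the oxygen link to the carbonyl carbon or with the four methyl groups on its ring, as compound 3 differs from the others in both. A (2,2,6,6-tetramethylpiperidin-4-yl)amino group and a piperidin-4-yloxy group on the same carbonyl carbon would separate these two features.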